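The source may report more compounds than this note shows. Statements on the series, on what has been measured and on what is new or still open speak of the compounds shown alone.

The two measured compounds share one core and were both examined in an ADME assay on HUVEC cells (Homo sapiens) for antiproliferative activity, read by MTT assay, with a stated time of 48 h; a lower number here means a stronger inhibitor, a higher number a weaker inhibitor. Compound 1 `Cc1cccc(-n2nncc2CN2C(=O)C3(C(C#N)=C(N)Oc4c3c3nc5ccccc5nc3c3ccccc43)c3ccccc32)c1` gave no number in this assay, only a limit of the assay, > 50000 nM. Compound 2 `Cc1cccc(-n2nncc2CN2C(=O)C3(C(C#N)=C(N)Oc4c(N)cc5nc6ccccc6nc5c43)c3ccccc32)c1` likewise reached only a limit in this assay, > 50000 nM. Going by the values given here, compound 2 thus stands at the edge of what this assay can report: its own value is a limit, and the single other value shown is a limit too, as the limit of > 50000 nM in this assay, at which 2 of the 2 values shown sit, records. Among the compounds with values here, no pair of compounds here gives two real numbers, so no measured step sets a scale for how much a structural change can move the result.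

Compound 3 `N#CC1=C(N)Oc2c(N)cc3nc4ccccc4nc3c2C12C(=O)N(Cc1cnnn1-c1c(F)cccc1F)c1ccccc12` differs from compound 2 at one point, on an aromatic nitrogen of the five-membered aromatic ring with three nitrogens, where (2,6-difluorophenyl in place of 3-methylphenyl on an aromatic nitrogen).

With compound 2 already at the limit, the expected step from compound 2 to compound 3, a number no higher from compound 2 to compound 3 (the limit leaves the size open), is none beyond the scatter. Compound 3 is therefore estimated at about 50000 nM, within a range from 20000 nM to 120000 nM, and most probably returns once more only a limit of this assay.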

Compound 3, half-maximal inhibitory concentration: > 50000 nM
Compound 3: no number, only a limit (the forecaster's own chance of this, stated with the estimate: 80%); the middle value lies on the limit itself.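

In this assay compound 3 gives > 50000 nM, a limit and not a number. Going by these compounds alone, compound 2 also stands at a limit, and no step from compound 2 to compound 3 can be read. The compounds shown leave open what real number any of them would give and whether any structural change moves the result, with every value at one edge: the limit of > 50000 nM in this assay, at which 3 of the 3 values shown sit.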